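This account rests on a few compounds, and the source may have more. Where it says the series, first, only, none or still open, it means among the compounds named here.

For the measured compounds named here, two sulfonamides of the shared core have numbers so far. Compound 1 `O=c1[nH]cc(S(=O)(=O)Nc2ccccc2-c2cn(-c3ccc(F)cc3)nn2)c(=O)[nH]1` gives 6390 nM in a functional assay on A549 cells (Homo sapiens) for antiproliferative activity, read by MTT assay, with a stated time of 24 h; a lower number here means a stronger inhibitor, a higher number a weaker inhibitor. Compound 2 `O=c1[nH]cc(S(=O)(=O)Nc2cccc(-c3cn(-c4ccccc4)nn3)c2)c(=O)[nH]1` gives 12700 nM in this assay, the higher of the two numbers, with compound 1 the nearer and the gap between them within the scatter. Compound 3 `O=c1[nH]cc(S(=O)(=O)Nc2cccc(-c3cn(-c4cccc(Cl)c4)nn3)c2)c(=O)[nH]1` differs from compound 2 by chloro in place of hydrogen on an aromatic carbon. Going by the values given here, no single-point step between measured compounds shows what this change does, so the step of a 1.4-fold lower number from compound 2 to compound 3 (0.15 log units; within the scatter) is expected to stay within the scatter or trend slightly lower. Compound 3 is estimated at 9000 nM, within 3000 nM to 25000 nM.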

Compound 3, half-maximal inhibitory concentration: 2430 nM
Compound 3: the middle estimate sits 3.7-fold (0.57 log units) above what was measured; measured number outside the range, below it.
By their numbers in this assay, from the lowest: compound 3; then compounds 1 and 2 (each within the scatter of the next).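

Phenyl to 3-chlorophenyl is the first single-place change in the series that can be read, and in this assay it gives a 5.2-fold lower number from compound 2 to compound 3 (0.72 log units; beyond the scatter). An aromatic carbon meta to a large group therefore accepts chloro, and the number responds to substitution at this place. No measurement shown here accounts for this step.

Open, as far as these compounds go, is whether the shift belongs to chloro alone or would also follow from bromo, methyl, an amine or a carboxylic acid at the same place. Also open, from the compounds shown here alone, is whether chloro on another carbon of that ring would give a similar step.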